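The source may report more compounds than this note shows. Statements on the series, on what has been measured and on what is new or still open speak of the compounds shown alone.

Going by the values given here, in a functional assay on the whole organism with Rattus norvegicus as the target (a lower number here means that less compound is needed, a higher number that more compound is needed for the effect), compound 1 `CCNc1cccc(NC(=O)C(=O)OCC)c1C#N` gives 0.03 mg/kg and compound 2 `CCCCNc1cccc(NC(=O)C(=O)OCC)c1C#N` gives 0.3 mg/kg, the higher of the two numbers so far. Compound 3 `CCOC(=O)C(=O)Nc1cccc(N(C)CC)c1C#N` differs from compound 2 as follows: ethyl(methyl)amino in place of butylamino on an aromatic carbon. Among the compounds with values here, only one measured step bears on this change, a 10-fold higher number from compound 1 to compound 2 (1.00 log units; beyond the scatter), in which the ethylamino group of the first compound gives way to the longer butylamino group. Within the data shown here, compound 3 also carries a shorter group than butylamino, but no measured compound has ethyl(methyl)amino, so only part of that step is expected to be reversed. The expected change is a lower number, a 3.0-fold lower number from compound 2 to compound 3 (0.48 log units; beyond the scatter). For compound 3 the estimate is 0.1 mg/kg, with an expected range of 0.02 mg/kg to 0.6 mg/kg.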

Compound 3, dose for half-maximal effect: 0.3 mg/kg
Compound 3: middle estimate off by 3.0-fold (0.48 log units), on the low side, and the stated range covers the measured number.
By their numbers in this assay, from the lowest: compound 1; then compounds 2 and 3 (each within the scatter of the next).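

In this assay, putting a methyl on the nitrogen of the ethylamino group gives a 10-fold higher number from compound 1 to compound 3 (1.00 log units; beyond the scatter), so at this position even that small addition counts. Replacing butylamino with ethyl(methyl)amino gives no change at the digits printed from compound 2 to compound 3 (within the scatter), which means that two different changes to compound 1, a longer chain and a methyl on the nitrogen, end at the same printed number. No measurement shown offers a reason for either result.

Open, going by these compounds, is how a propylamino group would compare with ethylamino and butylamino. Also open, on these data alone, is where an unsubstituted amino group or a dimethylamino group would fall.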